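Trimethylphenyl to dimethylphenyl on the shared core

This account rests on a few compounds, and the source may have more. Where it says the series, first, only, none or still open, it means among the compounds named here.

Among the measured compounds shown here, compound 1 `Cc1cc(C)c(Oc2cc(Nc3ccc(C#N)cc3)[nH]c(=O)c2I)c(C)c1` gives 34000 nM in an ADME assay on MT4 cells (Homo sapiens) for cytotoxicity, read by MTT assay, with a stated time of 5 days (on this read-out higher numbers stand for lower toxicity in this test and lower numbers for higher toxicity in this test), the only outright number among the measured values. Compound 2 `Cc1cc(C)c(Oc2cc(Nc3ccc(C#N)cc3)[nH]c(=O)c2Cl)c(C)c1` in this assay reaches only a limit, > 329000 nM. For the measured compounds named here, the one measured step, an at least 9.6-fold higher number from compound 1 to compound 2 (0.98 log units; beyond the scatter), is bounded by the limit of > 329000 nM in this assay, at which 1 of the 2 values shown sits, and concerns the halogen, not the ring carrying the methyls. Compound 3 `Cc1cccc(C)c1Oc1cc(Nc2ccc(C#N)cc2)[nH]c(=O)c1I` differs from compound 1 by hydrogen in place of methyl on an aromatic carbon. Going by the values given here, no measured step bears on this change, so no shift beyond the scatter in this assay is expected. Compound 3 is estimated at 34000 nM, with a range of 15000 nM to 80000 nM. The expected step is no change at the digits printed from compound 1 to compound 3 (within the scatter).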

Compound 3, half-maximal cytotoxic concentration: 28000 nM
Compound 3: the middle estimate sits 1.2-fold (0.08 log units) above what was measured; the range from low to high includes it.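

In this assay, going from 2,4,6-trimethylphenyl to 2,6-dimethylphenyl gives a 1.2-fold lower number from compound 1 to compound 3 (0.08 log units; within the scatter), so on the iodo compounds hydrogen can stand in place of the methyl para to a large group with no shift beyond the scatter. Among the compounds shown here, this is the first measured step on the ring carrying the methyls, as the earlier step concerned the halogen. Nothing measured here bears on the size of this step.

Still open, as far as these compounds go, is whether an amine or a methoxy group at this position would stay in the same range. Also open, from the compounds shown here alone, is whether this change behaves alike on the chloro compound 2, whose > 329000 nM is a limit of the assay.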